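The source may hold more compounds than are shown below. What is called first, only, known or untested is meant among the compounds shown, and "the series" means these compounds.

Measured compounds:
compound 1 `CCCC(=O)N(Cc1ccccc1)C1CCN(S(=O)(=O)c2c(C)cc(C)cc2C)CC1` — > 5000 nM in a functional assay on DLD-1 cells (Homo sapiens) for antiproliferative activity, read by CellTiter-Glo, with a stated time of 72 h; on this read-out lower numbers stand for stronger inhibition and higher numbers for weaker inhibition
compound 2 `Cc1cc(C)c(S(=O)(=O)N2CCC(N3CCN(C)CC3)CC2)c(C)c1` — 1100 nM

Compound 1 `CCCC(=O)N(Cc1ccccc1)C1CCN(S(=O)(=O)c2c(C)cc(C)cc2C)CC1` gives a limit rather than a number in this assay: its value of > 5000 nM marks the top of the assay range (the limit of > 5000 nM in this assay, at which 1 of the 2 values shown sits). For the measured compounds named here, compound 2 `Cc1cc(C)c(S(=O)(=O)N2CCC(N3CCN(C)CC3)CC2)c(C)c1` is the only compound with a measured number in this assay, at 1100 nM, so its standing cannot be placed against any other figure.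

Compound 3 `CCCC(=O)NC1CCN(S(=O)(=O)c2c(C)cc(C)cc2C)CC1` has not yet been measured in this assay. It differs from compound 2 by (propylcarbonyl)amino in place of 4-methylpiperazin-1-yl on a saturated ring carbon. Going by the values given here, no step between measured compounds exists to scale this change, so the expectation rests on the two values shown. Compound 3 is expected to be weaker than compound 2, with the step of a 3.6-fold higher number from compound 2 to compound 3 (0.56 log units; beyond the scatter) estimated to be beyond the usual scatter. Compound 3 is estimated at 4000 nM, with a range from 1200 nM to 15000 nM.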

Compound 3, half-maximal inhibitory concentration: > 5000 nM
Compound 3 was reported as a limit (the forecaster's own chance of this, stated with the estimate: 50%); middle value at least 1.2-fold (0.09 log units) away from the limit.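

Compound 3 shows that 4-methylpiperazin-1-yl on this saturated ring carbon cannot be exchanged for (propylcarbonyl)amino without a loss of activity in this assay: the change gives an at least 4.5-fold higher number from compound 2 to compound 3 (0.65 log units; beyond the scatter). Compound 3, which carries hydrogen in place of the benzyl on the amide-type nitrogen, still gives only a limit, as compound 1 does, so the step between these two cannot be read: the limit of > 5000 nM in this assay, at which 2 of the 3 values shown sit.

The compounds shown leave open whether the ring or the nitrogen atoms of 4-methylpiperazin-1-yl account for the activity of compound 2; a morpholin-4-yl or a dimethylamino group on this carbon would bear on that question. For the compounds shown here, with compound 2 the only measured number, how much stronger inhibition could become through changes at this position also remains open.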